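Trading one aromatic group for another on compound 3

The compounds below may be only part of what the source reports. "The series", "measured", "known", "first", "only" and "open" are said of these compounds alone.

Among the measured compounds shown here, in an ADME assay on TERT-RPE1 cells (Homo sapiens) for cytotoxicity, read by MTT assay, with a stated time of 72 h (on this read-out higher numbers stand for weaker inhibition and lower numbers for stronger inhibition), compound 3 `COc1ccc(/C=C2\S/C(=N\c3ccc(C)c(Cl)c3)N(C)C2=O)cc1` gives 23000 nM as the lower of the two true numbers so far. Compound 2 `COc1ccc(/C=C2/CN(C)/C(=N/c3ccc(C(F)(F)F)cc3)S2)cc1` gives 72000 nM as the higher one, a gap beyond the usual scatter, although compound 2 differs from compound 3 in more than one place. Compound 1 `C=CC/N=C1\S/C(=C\c2ccc(OC)cc2)C(=O)N1C` reads > 100000 nM and this is a limit, not a number.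

Compound 4 `COc1ccc(/C=C2\S/C(=N\c3ccc(Br)cc3)N(C)C2=O)cc1` carries 4-bromophenyl in place of 3-chloro-4-methylphenyl on a double-bonded nitrogen and is otherwise the same as compound 3.

For the measured compounds named here, one measured step bears on this change. It is an at least 4.3-fold lower number from compound 1 to compound 3 (0.63 log units; beyond the scatter) and it swapped allyl for 3-chloro-4-methylphenyl at the same nitrogen. Compound 4 keeps a six-membered aromatic ring there, so it does not undo that swap. Going by the values given here, no measured step compares two such aromatic groups, which leaves compound 3 at 23000 nM as the best anchor.

No shift beyond the scatter is therefore expected, and the expected change is a 1.2-fold higher number from compound 3 to compound 4 (0.09 log units; within the scatter) in either direction of little consequence. Compound 4 is estimated at 28000 nM with an expected range from 10000 nM to 70000 nM in this assay once measured.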

Compound 4, half-maximal inhibitory concentration: > 100000 nM
Compound 4 was reported as a limit (the forecaster's own chance of this, stated with the estimate: 10%); middle value at least 3.5-fold (0.55 log units) away from the limit.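

Both groups at this double-bonded nitrogen are a six-membered aromatic ring of carbon only, yet the two are not interchangeable in this assay, with an at least 4.3-fold higher number from compound 3 to compound 4 (0.63 log units; beyond the scatter). The earlier step from allyl to 3-chloro-4-methylphenyl could have suggested that any such aromatic ring at this nitrogen brings the number down, but compound 4 goes against that reading, so the result depends on which groups the ring carries. Compound 4 gives a limit rather than a number, as compound 1 does, so the step between these two compounds cannot be read and its size remains unknown: the limit of > 100000 nM in this assay, at which 2 of the 4 values shown sit.

The change from compound 3 to compound 4 removes a chlorine and a methyl group and adds a bromine in one move, so the compounds shown cannot say which of these edits accounts for the step. Plain phenyl, 4-methylphenyl or 3-chlorophenyl at the same nitrogen would pull these edits apart, and how far the true number of compound 4 lies from its limit also stays open.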